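Methoxy for methyl on the aniline ring of compound 1

The source may hold more compounds than are shown below. What is called first, only, known or untested is meant among the compounds shown, and "the series" means these compounds.

Going by the values given here, compound 1 `Cc1ccc(Nc2nnc(-c3ccccc3Cl)s2)cc1` is the lower of the two numbers so far: in an assay on isolated protein for inhibition of beta-glucuronidase (Bos taurus), read by spectrophotometry, with a stated time of 30 min (on this read-out higher numbers stand for weaker inhibition and lower numbers for stronger inhibition), compound 1 gives 16700 nM, while compound 2 `COc1ccccc1-c1nnc(Nc2ccc(C)cc2)s1` gives 58100 nM, with a 3.5-fold higher number from compound 1 to compound 2 (0.54 log units; beyond the scatter). Compound 3 `COc1ccc(Nc2nnc(-c3ccccc3Cl)s2)cc1` differs from compound 1 by methoxy in place of methyl on an aromatic carbon. Among the compounds with values here, no measured step changes this position; the only recorded step concerns the other ring, so it bears on compound 3 only loosely. The expected step is a 1.5-fold higher number from compound 1 to compound 3 (0.18 log units; within the scatter), likely within the scatter or a small weakening. Compound 3 is therefore estimated at 25000 nM, within a range from 8000 nM to 80000 nM.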

Compound 3, half-maximal inhibitory concentration: 22600 nM
The estimate for compound 3 lay 1.1-fold (0.04 log units) above the measured number; the measured number falls inside the stated range.
By their numbers in this assay, from the lowest: compounds 1 and 3 (each within the scatter of the next); then compound 2.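

At this position, para to a large group, methoxy in place of methyl gives a 1.4-fold higher number from compound 1 to compound 3 (0.13 log units; within the scatter), so this position tolerates the exchange on this read-out. Methoxy on the other ring, in place of chloro, gave a larger change: a 3.5-fold higher number from compound 1 to compound 2 (0.54 log units; beyond the scatter). No measurement on hand accounts for either step.

Still open, as far as these compounds go, is whether a hydroxyl, an amine or a carboxylic acid at this position would shift the number beyond the scatter. From the compounds shown here alone, a longer chain, such as ethoxy, also remains open here.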